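From benzyl to (methoxycarbonyl)methyl on an amide-type nitrogen

A few compounds are considered here, and "the series" means these few. Any claim that something is new, unique, unknown or untested is made for them only; others in the source may bear on it.

In a functional assay on HCT-116 cells (Homo sapiens) for antiproliferative activity, read by MTT assay, with a stated time of 72 h (on this read-out higher numbers stand for weaker inhibition and lower numbers for stronger inhibition), compound 1 (`C=CC(=O)Nc1ccc(Cl)c(S(=O)(=O)N(C)C)c1`) gives 24600 nM and compound 2 (`C=CC(=O)Nc1nc(-c2ccccc2F)cs1`) gives 20400 nM as measured numbers, and these two lie within the usual scatter of each other. Compound 3 (`C=CC(=O)N(Cc1ccccc1)c1nc(-c2ccccc2)cs1`) gives > 30000 nM as a limit of the assay and not a number, so its true position is not known.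

Compound 4 (`C=CC(=O)N(CC(=O)OC)c1nc(-c2ccccc2)cs1`) has not yet been measured. It differs from compound 3 by methoxycarbonyl in place of phenyl on a saturated chain carbon bound to an amide-type nitrogen, which also reads as benzyl to (methoxycarbonyl)methyl. Within the data shown here, no measured pair in this set differs in one place, so the data give no direct guide to the effect of this change.

The expected move in this assay is small, with nothing beyond the scatter anticipated and only a slight lean towards stronger inhibition. Among the measured compounds shown here, this expectation rests on compound 1 at 24600 nM and compound 2 at 20400 nM, the only numbers available. The estimate is an at least 1.1-fold lower number from compound 3 to compound 4 (0.06 log units; that floor lies within the scatter) and it is uncertain, since compound 4 may also end at a limit. Compound 4 is expected at an estimated 26000 nM (range 13000 nM to 40000 nM).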

Compound 4, half-maximal inhibitory concentration: > 30000 nM
Compound 4: no number, only a limit (the forecaster's own chance of this, stated with the estimate: 45%); at least 1.1-fold (0.06 log units) between middle value and limit.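

In this assay compound 4 gives > 30000 nM as a limit of the assay and not a number. Compound 3 gives > 30000 nM as a limit too, so no step can be read between compound 3 and compound 4: the limit of > 30000 nM in this assay, at which 2 of the 4 values shown sit.

From the compounds shown here alone, what stays open is whether methoxycarbonyl in place of phenyl at this place changes inhibition at all, and in which direction.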